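A few compounds are considered here, and "the series" means these few. Any claim that something is new, unique, unknown or untested is made for them only; others in the source may bear on it.

Measured so far in a functional assay on MCF7 cells (Homo sapiens) for cytotoxicity, read by MTT assay, with a stated time of 72 h; a lower number here means that less compound is tolerated, a higher number that more compound is tolerated:
- compound 1 `CCCCCCOC(=O)Nc1ccc([Se]C#N)cc1`, giving 63900 nM
- compound 2 `N#C[Se]c1ccc(NC(=O)OCc2ccc([N+](=O)[O-])cc2)cc1`, giving 69500 nM

The two numbers lie within the scatter of each other, so compound 2 is not separated from compound 1 in this assay. Compound 3 `N#C[Se]c1ccc(NC(=O)OCc2ccccc2)cc1` differs from compound 2 by hydrogen in place of nitro on an aromatic carbon, a hydrogen in place of nitro on an aromatic carbon. Within the data shown here, no comparable step is available among the measured pair. The change is expected to give no step beyond the scatter, a 1.1-fold lower number from compound 2 to compound 3 (0.03 log units; within the scatter). Compound 3 is therefore estimated at 65000 nM, with a range from 30000 nM to 140000 nM.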

Compound 3, concentration lethal to 50% of the cells: 68900 nM
Estimate against measurement, compound 3: 1.1-fold (0.03 log units) below, and the stated range covers the measured number.
By their numbers in this assay, from the lowest: compounds 1, 3 and 2 (each within the scatter of the next).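

In this assay, hydrogen in place of nitro on the aromatic carbon, para to a large group, gives a step within the scatter (a 1.0-fold lower number from compound 2 to compound 3 (0.00 log units; within the scatter)), so the nitro group is not separated from hydrogen at this position. Phenyl in place of pentyl on the saturated chain carbon also stays within the scatter (a 1.1-fold higher number from compound 1 to compound 3 (0.03 log units; within the scatter)). No evidence bears on either result.

On these data alone, whether an amine or a carboxylic acid on this aromatic carbon would give a step beyond the scatter remains open. The same holds for a longer chain in place of pentyl.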